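Capping the Carboxy Group of Compound 1 with Benzyl

The source may report more compounds than this note shows. Statements on the series, on what has been measured and on what is new or still open speak of the compounds shown alone.

Compound 1 `C[C@@H](O)[C@H](NC(=O)CN(c1nc(Cl)nc2[nH]cnc12)C1CC1)C(=O)O`: 35.9%
Compound 2 `CC(C)[C@H](NC(=O)CN(c1nc(Cl)nc2[nH]cnc12)C1CC1)C(=O)O`: 30.3%
Compound 3 `NC(=O)C[C@H](NC(=O)CN(c1nc(Cl)nc2[nH]cnc12)C1CC1)C(=O)O`: 20.1%

In a functional assay on the whole organism (Tail, strain ICR) with Mus musculus as the target, in the tail flick test, with a stated time of 90 min, at a dose of 25 umol/kg by the oral route (on this read-out higher numbers stand for a stronger effect at the one dose given and lower numbers for a weaker effect), compound 1 stands highest of the three measured numbers. Compound 2 lies within the scatter of it, as a number 5.6 percentage points lower from compound 1 to compound 2 (within the scatter) shows, while compound 3 sits lower, by a number 15.8 percentage points lower from compound 1 to compound 3 (beyond the scatter). Compound 4 `C[C@@H](O)[C@H](NC(=O)CN(c1nc(Cl)nc2[nH]cnc12)C1CC1)C(=O)OCc1ccccc1` differs from compound 1 in a single place: benzyl in place of hydrogen on an oxygen next to a carbonyl group, so that carboxy becomes benzyloxycarbonyl. Among the compounds with values here, none of the measured steps touches this oxygen; each of them changes only the group on the saturated chain carbon bound to an amide-type nitrogen and a carbonyl carbon. Within the data shown here, no measured step therefore bears on the new change, and its direction cannot be read from the data. Compound 4 is expected to give about 36%, between 15% and 58%, an expected step of a number 0.1 percentage points higher from compound 1 to compound 4 (within the scatter) that stays within the scatter.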

Compound 4, a percentage reported as activity, at one dose (the size of the read-out at that dose, not a potency): 29.9%
Estimate against measurement, compound 4: 6.1 percentage points above; measured number inside the range.
By their numbers in this assay, from the lowest: compounds 3, 4, 2 and 1 (each within the scatter of the next, the first and the last beyond it).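

Within the data shown here, this is the first change at the oxygen of the carboxy group rather than on the chain carbon, and in this assay benzyl on that oxygen gives a step that stays within the scatter: a number 6 percentage points lower from compound 1 to compound 4 (within the scatter). In this one pair, then, the read-out at this dose does not depend on keeping the hydrogen of the carboxy group. Nothing available explains why the two compounds read alike. Open, as far as these compounds go, is how methyl or ethyl on the same oxygen would read. Also open, from the compounds shown here alone, is whether benzyloxycarbonyl would behave the same way on compound 2 or compound 3.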